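Compound 3 to compound 4: adding a methyl at the limit

This account rests on a few compounds, and the source may have more. Where it says the series, first, only, none or still open, it means among the compounds named here.

Of the compounds shown here, three have been measured in an ADME assay on HepG2 cells (Homo sapiens) for inhibition, with a stated time of 48 h; a lower number here means that less compound is needed, a higher number that more compound is needed for the effect.

Compound 1 `CC(C(=O)N1CCOCC1)N1CCN(S(=O)(=O)c2ccc(C(C)(C)C)cc2)CC1`: a limit, > 40000 nM.
Compound 2 `CC(C(=O)N1CCCc2ccccc21)N1CCN(S(=O)(=O)c2ccc(C(C)(C)C)cc2)CC1`: a limit, > 40000 nM.
Compound 3 `CC(C)c1ccc(S(=O)(=O)N2CCN(C(C)C(=O)N3CCCC3)CC2)cc1`: a limit, > 40000 nM.

Compound 3 stands at the limit of this assay, where all three values shown sit (the limit of > 40000 nM in this assay, at which 3 of the 3 values shown sit). Going by the values given here, the only step between measured compounds, a step that the two limits leave unreadable from compound 1 to compound 2, is left unreadable by the two limits, so it offers no measure of size. Compound 4 `CCC(C)c1ccc(S(=O)(=O)N2CCN(C(C)C(=O)N3CCCC3)CC2)cc1` differs from compound 3 by methyl in place of hydrogen on a saturated chain carbon, two bonds along the chain from an aromatic carbon. Among the compounds with values here, no measured step touches that part of the structure, and the one step available has no readable size. The expectation for compound 4 is therefore that it stays at the limit, with a step that the limit leaves unreadable from compound 3 to compound 4 as the estimated step. Compound 4 is estimated at 60000 nM, within 20000 nM to 200000 nM.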

Compound 4, half-maximal effective concentration: > 40000 nM
Compound 4 was reported as a limit (the forecaster's own chance of this, stated with the estimate: 85%); the middle value does not contradict the limit.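

Compound 3 and compound 4 both sit at a limit in this assay, so no size can be read for the step between them: the limit of > 40000 nM in this assay, at which 4 of the 4 values shown sit.

The compounds shown leave open which change in structure, if any, would give a readable value in this assay.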